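This account rests on a few compounds, and the source may have more. Where it says the series, first, only, none or still open, it means among the compounds named here.

Compound 1 `COc1ccc(CNC(=O)/C(C#N)=C/c2ccc3ccccc3c2)cc1` and compound 3 `N#C/C(=C\c1ccc2ccccc2c1)C(=O)NCc1ccc(Cl)c(Cl)c1` share one core and differ only where (3,4-dichlorophenyl in place of 4-methoxyphenyl on a saturated chain carbon bound to an amide-type nitrogen). In a functional assay on NCI-H460 cells (Homo sapiens) for inhibition, read by MTT assay, with a stated time of 72 h (a higher number here means a weaker inhibitor of growth, a lower number a stronger inhibitor of growth), compound 1 gives > 100000 nM, which is a limit of the assay rather than a number. Compound 3 gives > 100000 nM in this assay, again a limit. The step that the two limits leave unreadable from compound 1 to compound 3 therefore cannot be read, because of the limit of > 100000 nM in this assay, at which 2 of the 3 values shown sit. Compound 2 `COc1ccc(CNC(=O)/C(C#N)=C/c2cccc3ccccc23)cc1` has the same atoms as compound 1 joined differently; the difference between the two cores is not broken down here. In this assay, among the measured compounds shown here, compound 2 gives 15000 nM, the only plain number among the three. Compound 4 `N#C/C(=C\c1cccc2ccccc12)C(=O)NCc1ccc(Cl)c(Cl)c1` is the unmeasured partner of compound 2, formed by the same change, (3,4-dichlorophenyl in place of 4-methoxyphenyl on a saturated chain carbon bound to an amide-type nitrogen). With the earlier step unreadable, the step of a 1.3-fold lower number from compound 2 to compound 4 (0.10 log units; within the scatter) is expected to be small, resting mainly on the value of compound 2. Compound 4 is thus estimated at 12000 nM, within 2000 nM to 100000 nM.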

Compound 4, concentration for 50% growth inhibition: 7000 nM
Compound 4: middle estimate off by 1.7-fold (0.23 log units), on the high side; measured number inside the range.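

In this assay, 3,4-dichlorophenyl in place of 4-methoxyphenyl gives a 2.1-fold lower number from compound 2 to compound 4 (0.33 log units; beyond the scatter). The same change on the core of compound 1, which leads to compound 3, cannot be read, because both values there are limits of the assay and not numbers: the limit of > 100000 nM in this assay, at which 2 of the 4 values shown sit. The change therefore has one readable result on one core, and this does not show whether it carries over from one core to the other.

The compounds shown leave open how a plain phenyl group would read in the same place on either core. They also leave open whether a carboxylic acid there would give a number on the core of compound 1.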